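Swapping a Fluorinated for a Chlorinated Aniline Substituent

The compounds below may be only part of what the source reports. "The series", "measured", "known", "first", "only" and "open" are said of these compounds alone.

Compound 1 `O=C1C(Nc2ccccc2F)=CC(=O)c2c1nc1n2[C@H]2OC[C@@H](O)[C@H]2OC1` is tested in a functional assay on ECa-109 cells for inhibition, with ECa-109 cell line (Homo sapiens) as the target, read by sulforhodamine B assay (on this read-out lower numbers stand for stronger inhibition and higher numbers for weaker inhibition), where compound 1 gives 2660 nM. Compound 3 `COc1cccc(NC2=CC(=O)c3nc4n(c3C2=O)[C@H]2OC[C@@H](O)[C@H]2OC4)c1` gives 7620 nM in this assay. For compound 2 `COc1ccc(NC2=CC(=O)c3nc4n(c3C2=O)[C@H]2OC[C@@H](O)[C@H]2OC4)cc1` the assay reports only a limit, > 4000 nM. Among the two numbers shown, compound 1 stands lowest, and its gap to the nearest one, compound 3, lies beyond the scatter. Among the measured compounds shown here, the only step between measured neighbours, a step that the limit leaves unreadable from compound 2 to compound 3, cannot be read because of the limit of > 4000 nM in this assay, at which 1 of the 3 values shown sits.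

Compound 4 `O=C1C(Nc2cccc(Cl)c2)=CC(=O)c2c1nc1n2[C@H]2OC[C@@H](O)[C@H]2OC1` differs from compound 1 in one place: 3-chlorophenyl in place of 2-fluorophenyl on an amine nitrogen. For the measured compounds named here, no measured step speaks to this change, since the single step at hand is unreadable. Compound 4 is therefore expected near 3500 nM, within 1200 nM to 10000 nM. The step is estimated as a 1.3-fold higher number from compound 1 to compound 4 (0.12 log units; within the scatter), plausibly within the scatter, in no fixed direction.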

Compound 4, half-maximal inhibitory concentration: 3080 nM
Compound 4: the middle estimate sits 1.1-fold (0.06 log units) above what was measured, and the stated range covers the measured number.
By their numbers in this assay, from the lowest: compounds 1 and 4 (each within the scatter of the next); then compound 3.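

On this amine nitrogen, 3-chlorophenyl in place of 2-fluorophenyl gives, in this assay, a 1.2-fold higher number from compound 1 to compound 4 (0.06 log units; within the scatter), the first readable step among these compounds. The two phenyl groups, which differ in both halogen and substitution position, thus cannot be told apart in this read-out. The step between the two methoxyphenyl compounds still cannot be read, because one of them carries a limit: the limit of > 4000 nM in this assay, at which 1 of the 4 values shown sits.

On these data alone, the share of the halogen and the share of its place on the phenyl ring in this step stay open. As far as these compounds go, how a pyridyl ring or a benzyl group on the same nitrogen would read also remains open.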